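The source may hold more compounds than are shown below. What is called first, only, known or untested is meant among the compounds shown, and "the series" means these compounds.

In a functional assay on MCF7 cells (Homo sapiens) for inhibition, read by MTT assay, with a stated time of 72 h (on this read-out lower numbers stand for stronger inhibition and higher numbers for weaker inhibition), compound 1 (`CC(=O)N1CCN(c2nnc3nncn3n2)CC1`) gives 13900 nM as its starting value. Two relatives with the same core have also been measured: compound 2 (`CCCNc1nnc2nncn2n1`) gives 19800 nM and compound 3 (`CCCCNc1nnc2nncn2n1`) gives 13700 nM on this scale. Compound 1 sits among these numbers, and all three lie within the scatter of one another, so they cannot be ranked.

The next structure is compound 4 (`CCCCC(=O)N1CCN(c2nnc3nncn3n2)CC1`), reached by this change: propyl in place of hydrogen on a saturated chain carbon bound to a carbonyl carbon here, propyl in place of hydrogen on a saturated chain carbon bound to a carbonyl carbon. In other words, a methyl end becomes a butyl end.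

For the measured compounds named here, only one measured step bears on this, and only loosely. It is a 1.4-fold lower number from compound 2 to compound 3 (0.16 log units; within the scatter) for a methyl in place of hydrogen on a saturated chain carbon, and it lies within the scatter. Going by the values given here, that step lengthens a different chain, and no measured pair shows a change at the carbon bound to the carbonyl carbon.

With so little evidence, no shift beyond the scatter is expected, and the expected step is a 1.3-fold lower number from compound 1 to compound 4 (0.10 log units; within the scatter) in this assay as a cautious guess. Compound 4 is estimated at 11000 nM (expected range 5000 nM to 23000 nM).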

Compound 4, half-maximal inhibitory concentration: 2760 nM
Compound 4: the middle estimate sits 4.0-fold (0.60 log units) above what was measured, and the stated range ends above it.
By their numbers in this assay, from the lowest: compound 4; then compounds 3, 1 and 2 (each within the scatter of the next).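

In this assay, turning the methyl end of compound 1 into a butyl end, with propyl in place of hydrogen on a saturated chain carbon bound to a carbonyl carbon, gives a 5.0-fold lower number from compound 1 to compound 4 (0.70 log units; beyond the scatter), the only step among these compounds that lies beyond the scatter. This shows that the number responds to a change at this position and that the added propyl is compatible with stronger inhibition, which compounds 1, 2 and 3 could not show while all three lay within the scatter of one another. The earlier step, a 1.4-fold lower number from compound 2 to compound 3 (0.16 log units; within the scatter), adds a methyl to a different chain at a different place, so it says little about this position, and nothing in the data shown explains why the longer chain gives the lower number.

Going by these compounds, it remains open whether the trend continues with a longer chain such as hexyl, or whether it survives branching, as in isobutyl, a phenyl ring at the chain end, or a terminal amine or carboxylic acid. A single pair also cannot tell whether the same change would have a similar effect on a different core.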